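The source may hold more compounds than are shown below. What is called first, only, known or untested is meant among the compounds shown, and "the series" means these compounds.

Working notes on a small sulfonylurea set.

Compound 1 `COc1ccc(OC)c(CNC(=O)NS(=O)(=O)c2ccc(Cl)cc2)c1` and compound 2 `COc1ccc(OC)c(CNC(=O)NS(=O)(=O)c2ccc(C)cc2)c1` share one core, while compound 3 `CC(NC(=O)NS(=O)(=O)c1ccc(Cl)cc1)c1ccccc1OCc1ccccc1` and compound 4 `Cc1ccc(S(=O)(=O)NC(=O)NC(C)c2ccccc2OCc2ccccc2)cc1` share another; the difference between the two cores is not broken down here.

In a functional assay on thoracic aorta (Rattus norvegicus, strain Wistar), with a stated time of 15 min (a higher number here means that more compound is needed for the effect, a lower number that less compound is needed), compound 1 gives only a limit, > 300000 nM. Compound 2 also gives only a limit in this assay, > 300000 nM. The change from compound 1 to compound 2 is methyl in place of chloro on an aromatic carbon. The step it made, a step that the two limits leave unreadable from compound 1 to compound 2, cannot be read because of the limit of > 300000 nM in this assay, at which 2 of the 3 values shown sit. Among the measured compounds shown here, compound 3 stands apart as the one compound with a number in this assay, giving 157000 nM.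

The same change, at the same kind of place, is now made from compound 3 to compound 4: methyl in place of chloro on an aromatic carbon. Since the earlier instance left no readable size, the expectation for compound 4 rests on the value of compound 3 alone, which gives 157000 nM in this assay. Compound 4 is therefore expected to sit close to that mark, estimated at 200000 nM in this assay, with a range from 80000 nM to 500000 nM. The step this estimate implies is a 1.3-fold higher number from compound 3 to compound 4 (0.11 log units; within the scatter), and a further limit rather than a number is a real possibility.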

Compound 4, half-maximal effective concentration: > 200000 nM
Compound 4: a limit, no number (the forecaster's own chance of this, stated with the estimate: 40%); the middle value lies on the limit itself.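

In this assay, compound 4 gives > 200000 nM, which is a limit and not a number. On the core of compound 3, the change from 4-chlorophenyl to 4-methylphenyl gives an at least 1.2-fold higher number from compound 3 to compound 4 (0.10 log units; that floor lies within the scatter); this is only a floor, so the data neither establish a real shift on this core nor fix its size. The matching step on the core of compound 1 cannot be read, and nothing here shows whether the change carries over from one core to the other with a similar size, because both compounds on that core give only a limit: the limit of > 300000 nM in this assay, at which 2 of the 4 values shown sit.

Still open, as far as these compounds go, is whether any other group at this place on the aromatic ring, such as methoxy, an amine or a carboxylic acid, would give a clear number in this assay on either core. Also open, from the compounds shown here alone, is how far the difference between the two cores matters by itself, and whether a change elsewhere on the core of compound 3, such as a hydroxyl group or a longer chain, would move the values away from the limits seen so far.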